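Distal aryl variation in a piperidine-triol glucosidase inhibitor series

The compounds below may be only part of what the source reports. "The series", "measured", "known", "first", "only" and "open" are said of these compounds alone.

Measured compounds:
compound 1, `COc1ccc(-c2ccc(COCCCCCN3C[C@H](O)[C@@H](O)[C@H](O)[C@H]3CO)cc2)cc1`, 10 nM
compound 2, `OC[C@@H]1[C@@H](O)[C@H](O)[C@@H](O)CN1CCCCCOCc1ccc(-c2ccccc2F)cc1`, 2 nM
compound 3, `OC[C@@H]1[C@@H](O)[C@H](O)[C@@H](O)CN1CCCCCOCc1ccc(-c2ccc(C(F)(F)F)cc2)cc1`, 10 nM

These three compounds were tested in an assay on isolated protein for inhibition of Beta-glucosidase (Homo sapiens); on this read-out higher numbers stand for weaker inhibition and lower numbers for stronger inhibition. Compound 3 stands level with compound 1 at the digits shown, the two together giving the highest numbers of the three, while compound 2 lies lowest; the step is a 5.0-fold higher number from compound 2 to compound 3 (0.70 log units; beyond the scatter), whereas the step is no change at the digits printed from compound 1 to compound 3 (within the scatter). Compound 4, `OC[C@@H]1[C@@H](O)[C@H](O)[C@@H](O)CN1CCCCCOCc1ccc(-c2ccnc(F)c2)cc1`, has not yet been measured. It differs from compound 3 by 2-fluoropyridin-4-yl in place of 4-(trifluoromethyl)phenyl on an aromatic carbon. Within the data shown here, the only measured steps at this position are no change at the digits printed from compound 1 to compound 3 (within the scatter), which was flat, and a 5.0-fold lower number from compound 1 to compound 2 (0.70 log units; beyond the scatter). Neither involves a ring nitrogen, so the step of a 1.3-fold lower number from compound 3 to compound 4 (0.10 log units; within the scatter) is expected to be small, within or near the scatter. Compound 4 is estimated at 8 nM in this assay, with a range from 3 nM to 25 nM.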

Compound 4, half-maximal inhibitory concentration: 4 nM
The estimate for compound 4 lay 2.0-fold (0.30 log units) above the measured number, within the range that was stated.
By their numbers in this assay, from the lowest: compounds 2 and 4 (each within the scatter of the next); then compounds 1 and 3 (each within the scatter of the next).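

In this assay the change to 2-fluoropyridin-4-yl shows that a ring nitrogen can enter this position without loss: it gives a 2.5-fold lower number from compound 3 to compound 4 (0.40 log units; beyond the scatter) and a 2.5-fold lower number from compound 1 to compound 4 (0.40 log units; beyond the scatter). Against the other fluorinated ring the result is a 2.0-fold higher number from compound 2 to compound 4 (0.30 log units; within the scatter), so compound 4 sits with compound 2 rather than with compounds 1 and 3. Nothing available explains this difference. The compounds shown leave open whether the ring nitrogen or the fluorine accounts for these steps. A plain pyridin-4-yl ring, or an amine in place of the fluorine, would bear on that.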